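Replacing trifluoromethyl with methyl on a hydroxylated side chain

The compounds below may be only part of what the source reports. "The series", "measured", "known", "first", "only" and "open" are said of these compounds alone.

In a functional assay on HT cells (Homo sapiens) for antiproliferative activity, read by fluorescence, with a stated time of 72 h (on this read-out lower numbers stand for stronger inhibition of growth and higher numbers for weaker inhibition of growth), compound 3 `CC(C)c1n[nH]c2c(NCc3ccc(-c4ccccn4)cc3)nc(SCC(O)C(F)(F)F)nc12` gives 690 nM as its reading. Compound 1 `CC(C)c1n[nH]c2c(NCc3ccc(-c4ccccn4)cc3)nc(SCC(N)CN)nc12` gives 480 nM as its number, and a 1.4-fold higher number from compound 1 to compound 3 (0.16 log units; within the scatter) shows that the two cannot be told apart. Clearly stronger than compound 3 is compound 2 `CC(C)c1n[nH]c2c(NCc3ccc(-c4ccccn4)cc3)nc(SCCO)nc12`, with 48 nM as its number.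

Compound 4 `CC(O)CSc1nc(NCc2ccc(-c3ccccn3)cc2)c2[nH]nc(C(C)C)c2n1` differs from compound 3 by a single swap methyl in place of trifluoromethyl on a saturated chain carbon bound to an oxygen on a saturated carbon and a saturated chain carbon that turns (3,3,3-trifluoro-2-hydroxypropyl)sulfanyl into (2-hydroxypropyl)sulfanyl. The closest evidence is a 14-fold higher number from compound 2 to compound 3 (1.16 log units; beyond the scatter) when trifluoromethyl takes the place of hydrogen on that same chain carbon. The other step, a 10-fold lower number from compound 1 to compound 2 (1.00 log units; beyond the scatter) for a different group, says less about this swap. Losing the trifluoromethyl may undo most of the large rise seen with compound 3, but methyl is not hydrogen and no measured compound carries it there. A step of a 7.7-fold lower number from compound 3 to compound 4 (0.88 log units; beyond the scatter) is therefore expected, towards stronger inhibition. For compound 4 the estimate is 90 nM with an expected range from 35 nM to 230 nM in this assay overall.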

Compound 4, concentration for 50% growth inhibition: 62 nM
The estimate for compound 4 lay 1.5-fold (0.16 log units) above the measured number; low and high end bracket the measured number.
By their numbers in this assay, from the lowest: compounds 2 and 4 (each within the scatter of the next); then compounds 1 and 3 (each within the scatter of the next).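

On the saturated chain carbon bound to the oxygen, the weaker inhibition of growth in this assay goes with trifluoromethyl in particular and not with any added group: replacing it with methyl gives an 11-fold lower number from compound 3 to compound 4 (1.05 log units; beyond the scatter), whereas adding methyl in place of hydrogen gives a 1.3-fold higher number from compound 2 to compound 4 (0.11 log units; within the scatter), so methyl and hydrogen cannot be told apart there. The methyl-bearing hydroxylated chain also shows the same advantage over the diamine chain as the unbranched hydroxylated chain does, with 1-hydroxyethyl in place of 1,2-diaminoethyl giving a 7.7-fold lower number from compound 1 to compound 4 (0.89 log units; beyond the scatter). Nothing measured here explains why these groups differ.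

Still open, on these data alone, is whether ethyl on this carbon would keep the reading in the range of compound 2 and compound 4. An amine or a carboxylic acid in place of the hydroxyl, or a longer chain, is equally untested in the compounds shown.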